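The compounds below may be only part of what the source reports. "The series", "measured", "known", "first", "only" and "open" are said of these compounds alone.

Within the data shown here, in a functional assay on HEY cells (Homo sapiens) for cytotoxicity, read by MTT assay, with a stated time of 72 h (a lower number here means a stronger inhibitor, a higher number a weaker inhibitor), compound 2 `N[C@H]1CC[C@H](Nc2c(C(=O)NCc3cccc(C(F)(F)F)c3)nc(Br)c3cccnc23)CC1` gives 12000 nM, the only number so far. Compound 1 `N[C@H]1CC[C@H](Nc2c(C(=O)NCc3ccco3)nc(Br)c3cccnc23)CC1` gives > 10000 nM, which is a limit of the assay and not a number. Among the measured compounds shown here, the one measured step is a step that the limit leaves unreadable from compound 1 to compound 2, and the relevant note is the limit of > 10000 nM in this assay, at which 1 of the 2 values shown sits. That step therefore provides no usable size.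

Compound 3 `N[C@H]1CC[C@H](Nc2c(C(=O)NC3CCCCC3)nc(Br)c3cccnc23)CC1` has cyclohexyl in place of 3-(trifluoromethyl)benzyl on an amide-type nitrogen, and the counted difference is cyclohexyl in place of 3-(trifluoromethyl)benzyl on an amide-type nitrogen. With no readable step to scale this change, the expectation rests on compound 2 at 12000 nM, and no shift beyond the scatter is expected in this assay, in either direction. The expected change is no change at the digits printed from compound 2 to compound 3 (within the scatter). A limit rather than a number is also a realistic expected outcome. For compound 3 the estimated value is 12000 nM, with an expected range of 5000 nM to 30000 nM.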

Compound 3, half-maximal inhibitory concentration: 5200 nM
Estimate against measurement, compound 3: 2.3-fold (0.36 log units) above, within the range that was stated.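

In this assay, the substituent on the amide-type nitrogen now gives a first readable step, as cyclohexyl in place of 3-(trifluoromethyl)benzyl gives a 2.3-fold lower number from compound 2 to compound 3 (0.36 log units; beyond the scatter). Cyclohexyl in place of (furan-2-yl)methyl gives an at least 1.9-fold lower number from compound 1 to compound 3 (0.28 log units; that floor lies within the scatter), so this second comparison sets only a floor and does not show a change beyond the scatter. That floor rests on a limit for compound 1 and not on a number: the limit of > 10000 nM in this assay, at which 1 of the 3 values shown sits.

The step to cyclohexyl changes the ring from aromatic to non-aromatic, removes the trifluoromethyl and alters the heavy-atom count all at once, and the compounds shown do not separate these changes. Unsubstituted benzyl and cyclohexylmethyl on the same amide nitrogen would be the closest comparisons, and how either reads remains open.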